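This account rests on a few compounds, and the source may have more. Where it says the series, first, only, none or still open, it means among the compounds named here.

Compound 1, `COc1cc(OCCCCOc2ccc(C(=O)CC(C)(C)C)c(O)c2C)cc(C(=O)O)c1`: 102 nM in an assay for positive allosteric modulation of metabotropic glutamate receptor 2 (Rattus norvegicus); on this read-out lower numbers stand for an effect already at smaller amounts and higher numbers for an effect only at larger amounts of compound
Compound 2, `Cc1c(OCCCCOc2ccc(F)c(C(=O)N(C)C)c2)ccc(C(=O)CC(C)(C)C)c1O`: 3810 nM in this assay
Compound 3, `Cc1cc(C(=O)O)ccc1OC[C@H](C)COc1ccc(C(=O)CC(C)(C)C)c(O)c1C`: 446 nM in this assay

Among these three, compound 3 holds the second highest number in this assay. Its nearest neighbour is compound 1, whose number is lower by a margin beyond the scatter; compound 2 lies furthest away, with a number higher by a margin also beyond the scatter. Compound 4, `Cc1c(OC[C@@H](C)COc2ccc(C(=O)O)c(F)c2)ccc(C(=O)CC(C)(C)C)c1O`, has not yet been measured. It differs from compound 3 in one place: 4-carboxy-3-fluorophenyl in place of 4-carboxy-2-methylphenyl on an oxygen on a saturated carbon. Among the measured compounds no pair differs in exactly one place, so no single step can be used as a guide to how this exchange may play out. Compound 1 shows that a carboxyphenyl group on the linker is compatible with a low number; compound 2, with fluorine but no carboxylic acid, shows a high one. On this basis compound 4 is expected to sit close to compound 3, with a step of a 1.1-fold higher number from compound 3 to compound 4 (0.05 log units; within the scatter) that need not exceed the scatter. The estimate for compound 4 in this assay is 500 nM, within a range from 150 nM to 1700 nM.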

Compound 4, half-maximal effective concentration: 261 nM
Compound 4: the middle estimate sits 1.9-fold (0.28 log units) above what was measured; measured number inside the range.
By their numbers in this assay, from the lowest: compound 1; then compounds 4 and 3 (each within the scatter of the next); then compound 2.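

In this assay, among these compounds, the exchange of 4-carboxy-2-methylphenyl for 4-carboxy-3-fluorophenyl, on an oxygen on a saturated carbon, gives a 1.7-fold lower number from compound 3 to compound 4 (0.23 log units; within the scatter) and provides the first comparison here of compounds that differ in one place. At this position, with the carboxy group kept, a methyl group can thus give way to a fluorine on the ring with a step that lies within the scatter, so the two groups cannot be told apart on this read-out. No measurement shown accounts for this outcome.

The compounds shown leave open how a plain 4-carboxyphenyl group, or a chlorine or methoxy group in place of the fluorine, would read at this position. They also leave open whether a tetrazole could stand in for the carboxylic acid here.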